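The compounds below may be only part of what the source reports. "The series", "measured", "known", "first", "only" and "open" are said of these compounds alone.

Compound 1, `COc1ccc(NC(=O)Nc2cc(C)nc3ccccc23)cc1`: in an ADME assay on BJ cells (Homo sapiens) for cytotoxicity, with a stated time of 72 h (a lower number here means that less compound is needed, a higher number that more compound is needed for the effect), compound 1 gives > 25000 nM, which is a limit of the assay.
Compound 2, `Cc1ccc(NC(=O)Nc2cc(C)nc3ccccc23)cc1`: in this assay compound 2 gives > 25000 nM, also a limit.
Compound 3, `Cc1cc(NC(=O)Nc2ccc(N(C)C)cc2)c2ccccc2n1`: in this assay compound 3 gives > 25000 nM, again a limit.

All three values sit at the same limit, (the limit of > 25000 nM in this assay, at which 3 of the 3 values shown sit), so compound 3 stands exactly where the other two stand, and none of the three can be set apart from the others. The steps among them, a step that the two limits leave unreadable from compound 1 to compound 2, a step that the two limits leave unreadable from compound 1 to compound 3 and a step that the two limits leave unreadable from compound 2 to compound 3, cannot be read in size or direction. Compound 4, `Cc1cc(NC(=O)Nc2ccc(SC(F)(F)F)cc2)c2ccccc2n1`, differs from compound 3 in one place: (trifluoromethyl)sulfanyl in place of dimethylamino on an aromatic carbon. Within the data shown here, no measured step bears on this change, so no direction can be drawn from the data. Compound 4 is therefore expected to sit near the same limit, a step of a number no higher from compound 3 to compound 4 (the limit leaves the size open). The estimate for compound 4 is 25000 nM, with a range from 8000 nM to 60000 nM.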

Compound 4, half-maximal effective concentration: > 25000 nM
Compound 4: no number, only a limit; the forecaster's own chance of this, stated with the estimate: 65%; the middle value sits exactly at the limit.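

In this assay compound 4 gives > 25000 nM, which is a limit and not a number. Its steps to compound 1, compound 2 and compound 3 therefore cannot be read: the limit of > 25000 nM in this assay, at which 4 of the 4 values shown sit.

The compounds shown leave open what concentration of any of these four would reach the effect in this assay.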